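Spiro series with triazolylmethyl amide arms: expectation for compound 3

This account rests on a few compounds, and the source may have more. Where it says the series, first, only, none or still open, it means among the compounds named here.

Measured so far:
compound 1 `N#CC1=C(N)Oc2c(c3nc4ccccc4nc3c3ccccc23)C12C(=O)N(Cc1cnnn1-c1ccc(S(N)(=O)=O)cc1)c1ccccc12`: 42200 nM
compound 2 `N#CC1=C(N)Oc2c(N)cc3nc4ccccc4nc3c2C12C(=O)N(Cc1cnnn1-c1ccccc1Br)c1ccccc12`: 38000 nM

In a functional assay on HepG2 cells (Homo sapiens) for antiproliferative activity, read by MTT assay, with a stated time of 48 h (on this read-out lower numbers stand for stronger inhibition and higher numbers for weaker inhibition), compound 1 gives 42200 nM and compound 2 gives 38000 nM; the two numbers sit within the scatter of each other, so neither is set apart. Compound 3 `Cc1ccc(C)c(-n2nncc2CN2C(=O)C3(C(C#N)=C(N)Oc4c(N)cc5nc6ccccc6nc5c43)c3ccccc32)c1` is not yet measured in this assay. It differs from compound 2 by 2,5-dimethylphenyl in place of 2-bromophenyl on an aromatic nitrogen. Going by the values given here, no step between measured compounds covers such a change, so the expected step of a 1.1-fold higher number from compound 2 to compound 3 (0.02 log units; within the scatter) is none beyond the scatter. Compound 3 is therefore estimated at 40000 nM in this assay, with a range from 15000 nM to 100000 nM.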

Compound 3, half-maximal inhibitory concentration: > 50000 nM
Compound 3 was reported as a limit; the forecaster's own chance of this, stated with the estimate: 15%; at least 1.2-fold (0.09 log units) between middle value and limit.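

In this assay compound 3 gives > 50000 nM, which is a limit of the assay and not a number. Placing 2,5-dimethylphenyl in place of 2-bromophenyl on the aromatic nitrogen gives an at least 1.3-fold higher number from compound 2 to compound 3 (0.11 log units; that floor lies within the scatter), the first step read at this position, and it is only a floor. The reading therefore rests on a bound: the limit of > 50000 nM in this assay, at which 1 of the 3 values shown sits.

From the compounds shown here alone, how far compound 3 lies beyond its limit stays open. Also open, going by these compounds, is whether a carboxylic acid or an amine on this phenyl ring would shift the number in either direction.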